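A few compounds are considered here, and "the series" means these few. Any claim that something is new, unique, unknown or untested is made for them only; others in the source may bear on it.

Of the compounds shown here, three have been tested in a functional assay on NCI-H1993 cells (Homo sapiens) for inhibition, read by CCK-8 assay, with a stated time of 72 h; on this read-out lower numbers stand for stronger inhibition and higher numbers for weaker inhibition. Compound 1 `Oc1nc2ncc(-c3ccccc3)nc2n1Cc1ccc2ncccc2c1` and compound 2 `Oc1nc2ncc(-c3ccncc3)nc2n1Cc1ccc2ncccc2c1` share one core, while compound 3 `CC(c1cc2cccnc2cc1F)n1cnc2ncc(-c3ccncc3)nc21` is built on a different one; the difference between the two cores is not broken down here. In this assay compound 1 gives > 10000 nM, which is a limit of the assay and not a number. Compound 2 in this assay likewise gives > 10000 nM, again a limit. Going by the values given here, compound 3 in this assay gives 171 nM, the only number among the three.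

Compound 4 `CC(c1cc2cccnc2cc1F)n1cnc2ncc(-c3ccccc3)nc21` has not yet been measured. It differs from compound 3 by phenyl in place of pyridin-4-yl on an aromatic carbon. The same change, at the same place, is made from compound 2 to compound 1: phenyl in place of pyridin-4-yl on an aromatic carbon. The measured step there, a step that the two limits leave unreadable from compound 2 to compound 1, has no readable size because of the limit of > 10000 nM in this assay, at which 2 of the 3 values shown sit. So the step from compound 3 to compound 4 has no measured counterpart to lean on.

Compound 4 is expected to come in at 500 nM in this assay, with a likely range from 150 nM to 3000 nM. This estimate corresponds to an expected step of a 2.9-fold higher number from compound 3 to compound 4 (0.47 log units; beyond the scatter). Among the compounds with values here, it rests on compound 3 and its value of 171 nM as the only number available, allowing for some loss on the change. The two limits of compound 1 and compound 2 give no direction.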

Compound 4, half-maximal inhibitory concentration: 570 nM
Compound 4: middle estimate off by 1.1-fold (0.06 log units), on the low side, within the range that was stated.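

In this assay, putting phenyl in place of pyridin-4-yl on the core of compound 3 gives a 3.3-fold higher number from compound 3 to compound 4 (0.52 log units; beyond the scatter), a modest weakening that is a genuine reading on this core. The same change on the other core, from compound 2 to compound 1, cannot be read, because both of those compounds sit at a limit of the assay and neither gives a number: the limit of > 10000 nM in this assay, at which 2 of the 4 values shown sit. This leaves one readable step on one core, so it shows what the change does there, but it does not show whether the change keeps its size, or even its direction, when carried to the other core.

Still open, from the compounds shown here alone, is how other groups would behave at this same aromatic carbon, for example an amine, a carboxylic acid, a methoxy group or a pyridin-3-yl ring, and whether any of them would give a lower number than pyridin-4-yl does in compound 3. Also open is which of the differences between the two cores matters most, as no pair among the compounds shown isolates any one of those differences in a single change.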